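A few compounds are considered here, and "the series" means these few. Any claim that something is new, unique, unknown or untested is made for them only; others in the source may bear on it.

Measured so far:
compound 1 `CN(C)CCCNc1nc(-c2ccc(NC(=O)Nc3ccc(F)cc3)cc2)nc2c(Cl)c(Cl)sc12`, which in a functional assay on MKN-45 cells (Homo sapiens) for cytotoxicity, read by MTT assay, with a stated time of 72 h (a higher number here means a weaker inhibitor, a lower number a stronger inhibitor), gives 1120 nM;
compound 2 `CN(C)CCNc1nc(-c2ccc(NC(=O)Nc3ccc(F)cc3)cc2)nc2c(Cl)c(Cl)sc12`, which gives 1350 nM;
compound 3 `CCN(CC)CCNc1nc(-c2ccc(NC(=O)Nc3ccc(F)cc3)cc2)nc2c(Cl)c(Cl)sc12`, which gives 1370 nM.

All three numbers sit together. The steps of a 1.2-fold higher number from compound 1 to compound 2 (0.08 log units; within the scatter), a 1.2-fold higher number from compound 1 to compound 3 (0.09 log units; within the scatter) and a 1.0-fold higher number from compound 2 to compound 3 (0.01 log units; within the scatter) are each within the scatter, so compound 3 cannot be set apart from compound 1 or compound 2 on these numbers; the three amine variants on the chain read as one value.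

Compound 4 `CCN(CC)CCNc1nc(-c2ccc(NC(=O)Nc3ccc(C)cc3)cc2)nc2c(Cl)c(Cl)sc12` differs from compound 3 by methyl in place of fluoro on an aromatic carbon. Among the compounds with values here, none of the measured steps touches this part of the molecule: every step so far changes the amine on the chain, and every one of them stayed within the scatter. Within the data shown here, there is therefore no measured step that bears on the exchange of fluoro for methyl on the outer ring, and no basis for expecting a shift beyond the scatter in either direction.

The expected step of a 1.0-fold higher number from compound 3 to compound 4 (0.01 log units; within the scatter) is accordingly set as no change beyond the scatter. Compound 4 is estimated at 1400 nM, with a range of 600 nM to 3300 nM to allow for the untested position.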

Compound 4, half-maximal inhibitory concentration: 1450 nM
Compound 4: the middle estimate sits 1.0-fold (0.02 log units) below what was measured; the range from low to high includes it.
By their numbers in this assay, from the lowest: compounds 1, 2, 3 and 4 (each within the scatter of the next).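

In this assay, the exchange of fluoro for methyl on an aromatic carbon, para to a large group, gives a step (a 1.1-fold higher number from compound 3 to compound 4 (0.02 log units; within the scatter)) that is the only one shown outside the amine on the chain, and it too stays within the scatter. The earlier compounds shown here said nothing about this ring; with the diethylamino chain held fixed, the 4-fluorophenyl and 4-methylphenyl compounds now read as one value, so this position accepts either group without a shift that can be told from the scatter. No measurement at hand gives a reason for this result.

Open, from the compounds shown here alone, is whether a larger or different group in the same place, such as trifluoromethyl, methoxy or a carboxylic acid, would also stay within the scatter in this assay, since a single exchange between two small groups marks no limit for this position. Also open, going by these compounds, is whether the same exchange reads alike with dimethylamino on the chain, and whether a cyclic amine such as morpholine on the chain would separate from the three amine variants.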